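The compounds below may be only part of what the source reports. "The series", "measured", "known", "first", "only" and "open" are said of these compounds alone.

Compound 2 `COc1ccc(C2CC(c3cc(Cl)c(C)cc3O)=NN2c2ccc(S(N)(=O)=O)cc2)cc1OC` gives 62700 nM in a functional assay on SK-MEL-28 cells (Homo sapiens) for antiproliferative activity, with a stated time of 48 h; on this read-out higher numbers stand for lower toxicity in this test and lower numbers for higher toxicity in this test; compound 1 `Cc1cc(O)c(C2=NN(c3ccc(S(N)(=O)=O)cc3)C(/C=C/c3ccccc3)C2)cc1Cl` gives 52000 nM, and the two numbers sit within the scatter of each other, so neither stands apart. Compound 3 `COc1ccc(C2CC(c3cc(Cl)c(C)cc3O)=NN2c2ccc(S(N)(=O)=O)cc2)c(OC)c1OC` differs from compound 2 by methoxy in place of hydrogen on an aromatic carbon. Within the data shown here, the only measured step, a 1.2-fold higher number from compound 1 to compound 2 (0.08 log units; within the scatter), exchanged the whole group on the saturated ring carbon rather than adding a methoxy, so it bears on this change only loosely and was itself within the scatter. No movement beyond the scatter is therefore expected in this assay. For compound 3 the estimate is 62700 nM, ranging from 30000 nM to 130000 nM. That expectation amounts to no change at the digits printed from compound 2 to compound 3 (within the scatter).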

Compound 3, concentration lethal to 50% of the cells: 26800 nM
Beside the measured number, compound 3's estimate is 2.3-fold (0.37 log units) above it, outside the stated range (below it).
By their numbers in this assay, from the lowest: compounds 3, 1 and 2 (each within the scatter of the next, the first and the last beyond it).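

In this assay methoxy in place of hydrogen on this aromatic carbon, ortho to a large group and ortho to a methoxy group, gives a 2.3-fold lower number from compound 2 to compound 3 (0.37 log units; beyond the scatter) and is the only step among these compounds beyond the scatter. The exchange of 2-phenylethenyl for 2,3,4-trimethoxyphenyl reads a 1.9-fold lower number from compound 1 to compound 3 (0.29 log units; within the scatter) and stays within the scatter, so compound 3 stands apart from compound 2 only. Nothing at hand explains the lower number. Whether it belongs to methoxy itself stays open, since the compounds shown carry no other group on this carbon, such as an amine or a longer alkoxy chain.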